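The source may report more compounds than this note shows. Statements on the series, on what has been measured and on what is new or still open speak of the compounds shown alone.

Compound 3 `CCCN(CCC)c1cc(C)nc2c(-c3ncc(I)cc3C)c(C)nn12` gives 6.6 nM in an assay on isolated protein for binding affinity to corticotropin-releasing factor receptor 1 (Homo sapiens) (a higher number here means a weaker inhibitor, a lower number a stronger inhibitor), the smallest of the three numbers, though not apart from its neighbours: the steps of a 1.0-fold lower number from compound 2 to compound 3 (0.01 log units; within the scatter) and a 1.4-fold lower number from compound 1 to compound 3 (0.14 log units; within the scatter) both sit within the scatter. Compound 2 `CCCN(CCC)c1cc(C)nc2c(-c3ncc(Cl)cc3C)c(C)nn12` gives 6.7 nM and compound 1 `CCCN(CCC)c1cc(C)nc2c(-c3ncc([N+](=O)[O-])cc3C)c(C)nn12` gives 9.1 nM in this assay, with a 1.4-fold lower number from compound 1 to compound 2 (0.13 log units; within the scatter) also within the scatter. Compound 4 `CCCN(CCC)c1cc(C)nc2c(-c3ncccc3C)c(C)nn12` carries the change (hydrogen in place of iodo on an aromatic carbon). The measured steps exchange one substituent for another at this carbon and never remove it, so they bound the step only loosely; removal of the iodo is expected to cost a little, as a step of a 2.1-fold higher number from compound 3 to compound 4 (0.33 log units; beyond the scatter) that may still fall within the scatter. Compound 4 is thus estimated at 14 nM, within 5 nM to 45 nM.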

Compound 4, inhibition constant: 110 nM
For compound 4 the middle estimate is 7.9-fold (0.90 log units) below the measured one, outside the stated range (above it).
By their numbers in this assay, from the lowest: compounds 3, 2 and 1 (each within the scatter of the next); then compound 4.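

Any of the three substituents at this carbon matters far more than which one is present: removal gives a 17-fold higher number from compound 3 to compound 4 (1.22 log units; beyond the scatter) and, with the other two groups, a 16-fold higher number from compound 2 to compound 4 (1.22 log units; beyond the scatter) and a 12-fold higher number from compound 1 to compound 4 (1.08 log units; beyond the scatter) as well. Iodo, chloro and nitro remain within the scatter of each other, so only the step to hydrogen separates compounds here. Nothing available bears on the cause of this loss. Open, on these data alone, is whether fluoro, methyl, an amine or a carboxylic acid at this carbon would stay with the three substituted compounds or move towards compound 4.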